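The source may report more compounds than this note shows. Statements on the series, on what has been measured and on what is new or still open speak of the compounds shown alone.

In an ADME assay (liver) for pharmacokinetics, with Liver microsome (Rattus norvegicus) as the target, read by LC-MS, using microsomes, tested at 2 uM (a lower number here means slower removal, a higher number faster removal of the compound), compound 1 (`COCCOc1ncc(C(=O)N[C@@H]2CCCC[C@H]2O)cc1-c1ccc(Cl)cc1`) gives 0.098 mL/min/kg and compound 2 (`O=C(N[C@@H]1CCCC[C@H]1O)c1cnc(OCC(F)(F)F)c(-c2ccc(Cl)cc2)c1`) gives 0.023 mL/min/kg while compound 3 (`O=C(N[C@@H]1CCCC[C@H]1O)c1cnc(OCc2ncccn2)c(-c2ccc(Cl)cc2)c1`) gives 0.012 mL/min/kg on the same shared core with one group changed. Going by the values given here, the measurements show a 1.9-fold lower number from compound 2 to compound 3 (0.28 log units; within the scatter) as the one step inside the scatter, and a 4.3-fold lower number from compound 1 to compound 2 (0.63 log units; beyond the scatter) and an 8.2-fold lower number from compound 1 to compound 3 (0.91 log units; beyond the scatter) as steps beyond it. Compound 3 therefore stands clearly under compound 1 and level with compound 2 within the scatter.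

Compound 4 (`CN(CC1CC1)c1ncc(C(=O)N[C@@H]2CCCC[C@H]2O)cc1-c1ccc(Cl)cc1`) carries (cyclopropylmethyl)(methyl)amino in place of (pyrimidin-2-yl)methoxy on an aromatic carbon para to a (2-hydroxycyclohexyl)carbamoyl group and ortho to a 4-chlorophenyl group. The three measured steps all keep the oxygen on the aromatic ring and vary only what it carries, so none tests this exchange directly. Among the compounds with values here, their spread is the only guide: compound 1 at 0.098 mL/min/kg shows that a group without the pyrimidin-2-yl ring can stand well above compound 3, although compound 2 at 0.023 mL/min/kg shows that it need not. A rise is therefore expected, of about the size of the largest measured step. The expected step is a 4.2-fold higher number from compound 3 to compound 4 (0.62 log units; beyond the scatter) in this assay with wide uncertainty. Compound 4 is estimated at 0.05 mL/min/kg (expected range 0.015 mL/min/kg to 0.2 mL/min/kg).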

Compound 4, clearance: 1.73 mL/min/kg
For compound 4 the middle estimate is 35-fold (1.54 log units) below the measured one; the measured number lies above the stated range.
By their numbers in this assay, from the lowest: compounds 3 and 2 (each within the scatter of the next); then compound 1; then compound 4.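

The change at this position reaches far beyond anything the oxygen-bound groups showed: in this assay, replacing (pyrimidin-2-yl)methoxy with (cyclopropylmethyl)(methyl)amino gives a 140-fold higher number from compound 3 to compound 4 (2.16 log units; beyond the scatter), replacing 2,2,2-trifluoroethoxy gives a 75-fold higher number from compound 2 to compound 4 (1.88 log units; beyond the scatter), and replacing 2-methoxyethoxy gives an 18-fold higher number from compound 1 to compound 4 (1.25 log units; beyond the scatter). Going by these compounds alone, all three steps are large, and each exceeds the widest step seen when only the group on the oxygen varied, an 8.2-fold lower number from compound 1 to compound 3 (0.91 log units; beyond the scatter), so the number at this aromatic carbon, next to the ring nitrogen, can move much further than the earlier compounds indicated. Nothing presented here accounts for the size of this rise.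

The compounds shown leave open whether the rise follows from the amine nitrogen on the aromatic carbon or from the cyclopropylmethyl and methyl groups it carries, since both change together in compound 4. A cyclopropylmethoxy group at the same carbon, or a (pyrimidin-2-yl)methylamino group, would separate the two, and a smaller dimethylamino group would show how much of the rise remains without the cyclopropyl ring.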